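Chloro to trifluoromethyl on the aryl group of the core

The source may report more compounds than this note shows. Statements on the series, on what has been measured and on what is new or still open speak of the compounds shown alone.

Of the compounds shown here, three have been measured in a functional assay on HL-60 cells (Homo sapiens) for activation, read by flow cytometry, with a stated time of 4 days; a lower number here means that less compound is needed, a higher number that more compound is needed for the effect. Compound 1 `Fc1ccc(-c2cc3c(cn2)ncn3-c2ccc(OC(F)F)cc2)c(Cl)c1` gives 90 nM. Compound 2 `Fc1ccc(-c2cc3c(cn2)ncn3-c2ccc(OC(F)F)cc2)c(C(F)(F)F)c1` gives 1500 nM. Compound 3 `Cc1cc(Cl)ccc1-c1cc2c(cn1)ncn2-c1ccc(OC(F)F)cc1` gives 28 nM, the lowest of the three numbers.

Two single changes link the measured compounds. From compound 1 to compound 2 the change is trifluoromethyl in place of chloro on an aromatic carbon; in this assay a 17-fold higher number from compound 1 to compound 2 (1.22 log units; beyond the scatter). From compound 1 to compound 3 the aryl group on the shared core is exchanged: 4-chloro-2-methylphenyl in place of 2-chloro-4-fluorophenyl on an aromatic carbon; in this assay a 3.2-fold lower number from compound 1 to compound 3 (0.51 log units; beyond the scatter). Compounds 2 and 3 are not joined by a single change; their two values stand as shown.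

Compound 4 `Cc1cc(C(F)(F)F)ccc1-c1cc2c(cn1)ncn2-c1ccc(OC(F)F)cc1` has not yet been measured. It differs from compound 3 thus: trifluoromethyl in place of chloro on an aromatic carbon. This is the same kind of change as that from compound 1 to compound 2, and it occurs twice among the compounds shown, but the surroundings differ: in compound 1 the place is ortho to a large group and meta to a fluoro group, in compound 3 it is meta to a methyl group and para to a large group. Because a 17-fold higher number from compound 1 to compound 2 (1.22 log units; beyond the scatter) is large, a higher number is expected for compound 4 as well; the different surroundings leave the size open, so a somewhat smaller step is expected, a 7.1-fold higher number from compound 3 to compound 4 (0.85 log units; beyond the scatter). Compound 4 is expected to give 200 nM in this assay, within 50 nM to 900 nM.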

Compound 4, half-maximal effective concentration: 1000 nM
Compound 4: middle estimate off by 5.0-fold (0.70 log units), on the low side; the measured number lies above the stated range.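

In this assay, trifluoromethyl in place of chloro again raises the number, with a 36-fold higher number from compound 3 to compound 4 (1.55 log units; beyond the scatter), so chloro gives the lower number in both matched pairs. The step therefore carries over from the aryl group of compound 1 to that of compound 3 in direction, and the two sizes cannot be told apart: the same change on two cores in this assay, a 17-fold higher number (1.22 log units; beyond the scatter) from compound 1 to compound 2 and a 36-fold higher number (1.55 log units; beyond the scatter) from compound 3 to compound 4, 2.1-fold (0.33 log units) apart, within the scatter of two such steps. This holds for two pairs only, in one assay, with the place of the change differing between them, so it does not show that the step would be the same on other aryl groups or on a different core, and it gives no reason why trifluoromethyl costs so much here.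

Going by these compounds, what a nitrile, a methoxy group or an amine would give in place of chloro remains open, so it cannot be said whether the higher number is peculiar to trifluoromethyl or is shared by other groups at this place. Also open is whether the step keeps its size when the difluoromethoxy group, common to all the compounds shown, gives way to a carboxylic acid or a longer chain.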